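This account rests on a few compounds, and the source may have more. Where it says the series, first, only, none or still open, it means among the compounds named here.

Compound 1 `Cc1nn(-c2ncnc3nc[nH]c23)c2c1C(c1ccc(F)cc1Cl)CC(=O)N2` gives 9 nM in a functional assay on HEK293 cells for agonist activity at G-protein coupled receptor 39 (Homo sapiens), read by scintillation proximity assay and inositol phosphate accumulation, with a stated time of 75 min, in the presence of a further agent that is not named here (a higher number here means that more compound is needed for the effect, a lower number that less compound is needed), the lower of the two numbers in hand. Compound 2 `C=CCN1c2c(n(C)c(=O)n(C)c2=O)NC1N/N=C/c1ccc(O)cc1O` gives 340 nM in this assay, a gap from compound 1 that lies beyond the usual scatter. Compound 3 `Cc1nn(-c2ncnc3nc[nH]c23)c2c1C(OCCn1cccn1)CC(=O)N2` differs from compound 1 in one place: 2-(1H-pyrazol-1-yl)ethoxy in place of 2-chloro-4-fluorophenyl on a saturated ring carbon. Within the data shown here, no pair of measured compounds shares this change, so nothing in the data fixes its size. Compound 3 is expected to need more compound, with the estimated step being an 11-fold higher number from compound 1 to compound 3 (1.05 log units; beyond the scatter). Compound 3 is estimated at 100 nM, with a range from 20 nM to 600 nM.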

Compound 3, half-maximal effective concentration: 16 nM
Beside the measured number, compound 3's estimate is 6.3-fold (0.80 log units) above it; measured number outside the range, below it.
By their numbers in this assay, from the lowest: compounds 1 and 3 (each within the scatter of the next); then compound 2.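

On a saturated ring carbon of the shared core, 2-(1H-pyrazol-1-yl)ethoxy in place of 2-chloro-4-fluorophenyl comes to a 1.8-fold higher number from compound 1 to compound 3 (0.25 log units; within the scatter) in this assay, so a six-membered aromatic ring of carbon only is not needed at this position for a low number. The two groups differ in ring type and in hydrogen-bond acceptors, yet their compounds lie within the scatter of each other. Nothing measured here explains this result. From the compounds shown here alone, what an amine or a carboxylic acid in place of the pyrazole would give stays open, as does the effect of a longer chain carrying the pyrazole.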